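Compound 3 and the 4-phenylphenyl change in compound 4

A few compounds are considered here, and "the series" means these few. Any claim that something is new, unique, unknown or untested is made for them only; others in the source may bear on it.

Values so far in a functional assay on A549 cells (Homo sapiens) for antiproliferative activity, read by MTT assay, with a stated time of 48 h (a lower number here means a stronger inhibitor, a higher number a weaker inhibitor), are these:
Compound 1 `COc1ccc(/C=C/c2cc(OC)cc(OC)c2/C=C/C(=O)c2ccc(C)cc2)cc1` gives 3.6 ug/mL
Compound 2 `COc1ccc(/C=C/c2cc(OC)cc(OC)c2/C=C/C(=O)c2ccc(Cl)cc2)cc1` gives 6.4 ug/mL
Compound 3 `COc1ccc(/C=C/c2cc(OC)cc(OC)c2/C=C/C(=O)c2ccc(C)cc2C)cc1` gives 0.3 ug/mL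

Compound 3 has the lowest number of the three and is the strongest inhibitor among them. Two steps lead to it: a 12-fold lower number from compound 1 to compound 3 (1.08 log units; beyond the scatter) with methyl in place of hydrogen on an aromatic carbon, and a 21-fold lower number from compound 2 to compound 3 (1.33 log units; beyond the scatter) with 2,4-dimethylphenyl in place of 4-chlorophenyl on a carbonyl carbon. The remaining step of a 1.8-fold higher number from compound 1 to compound 2 (0.25 log units; within the scatter) stays small by comparison.

The next structure is compound 4 `COc1ccc(/C=C/c2cc(OC)cc(OC)c2/C=C/C(=O)c2ccc(-c3ccccc3)cc2)cc1` with the change 4-phenylphenyl in place of 2,4-dimethylphenyl on a carbonyl carbon in its makeup. It lacks the added methyl of the first step, as compound 1 and compound 2 do. Among these three the low number is so far seen only with the 2,4-dimethylphenyl group. A large step toward a higher number is therefore expected, estimated as a 13-fold higher number from compound 3 to compound 4 (1.12 log units; beyond the scatter) in size. For the measured compounds named here, no measured compound carries 4-phenylphenyl, so the expected range is kept wide. In this assay compound 4 is estimated at 4 ug/mL with an expected range from 1.2 ug/mL to 12 ug/mL once it is measured.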

Compound 4, half-maximal inhibitory concentration: 4.6 ug/mL
For compound 4 the middle estimate is 1.2-fold (0.06 log units) below the measured one, within the range that was stated.
By their numbers in this assay, from the lowest: compound 3; then compounds 1, 4 and 2 (each within the scatter of the next).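

In this assay the 4-phenylphenyl group on the carbonyl carbon gives a 15-fold higher number from compound 3 to compound 4 (1.19 log units; beyond the scatter) and so does not keep the low number seen with 2,4-dimethylphenyl, even though it enters with more heavy atoms and a second aromatic ring. Phenyl in place of chloro gives a 1.4-fold lower number from compound 2 to compound 4 (0.14 log units; within the scatter) and phenyl in place of methyl gives a 1.3-fold higher number from compound 1 to compound 4 (0.11 log units; within the scatter) and so methyl, chloro and phenyl on that aromatic carbon cannot be told apart, which leaves compound 3 alone as the strongest inhibitor of the four. Nothing given here accounts for these numbers.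

The compounds shown leave open whether 2-methylphenyl alone would keep the low number of compound 3. They also leave open how 2,4-dichlorophenyl, or a phenyl group carrying an amine or a carboxylic acid, would read in this assay.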